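Nitro to chloro swap on a weak cytotoxic series

A few compounds are considered here, and "the series" means these few. Any claim that something is new, unique, unknown or untested is made for them only; others in the source may bear on it.

Measured so far:
compound 1 `CC(=O)N1N=C(c2ccc(Br)cc2)CC1c1cccc(Cl)c1Cl`, 45700 nM
compound 2 `CC(=O)N1N=C(c2ccco2)CC1c1ccccc1[N+](=O)[O-]`, 27900 nM
compound 3 `CC(=O)N1N=C(c2ccco2)CC1c1ccc([N+](=O)[O-])cc1`, 35800 nM

All three were run in a functional assay on IMR-32 cells (Homo sapiens) for cytotoxicity, read by sulforhodamine B assay, with a stated time of 48 h; a higher number here means a weaker inhibitor, a lower number a stronger inhibitor. Compound 3 gives 35800 nM, which is the second highest of the three numbers. Its nearest neighbour is compound 1 at 45700 nM, and its furthest is compound 2 at 27900 nM; both of these gaps lie within the scatter of the assay, so no order among the three can be read from them. The whole set sits in a weakly active range.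

Compound 4 `CC(=O)N1N=C(c2ccco2)CC1c1ccc(Cl)cc1` has not been measured. It differs from compound 3 in one place: chloro in place of nitro on an aromatic carbon.

For the measured compounds named here, no pair of measured compounds differs in a single place, so there is no comparable step to lean on. Given that the three measured numbers in this assay are all close to one another, the expected step from compound 3 to compound 4 is a 1.0-fold lower number from compound 3 to compound 4 (0.01 log units; within the scatter), that is, none beyond the scatter. Compound 4 is therefore estimated at 35000 nM, with a range from 15000 nM to 80000 nM.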

Compound 4, half-maximal inhibitory concentration: 38900 nM
The estimate for compound 4 lay 1.1-fold (0.05 log units) below the measured number; low and high end bracket the measured number.
By their numbers in this assay, from the lowest: compounds 2, 3, 4 and 1 (each within the scatter of the next).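

In this assay, the series now has its first comparison in a single place: chloro in place of nitro gives a 1.1-fold higher number from compound 3 to compound 4 (0.04 log units; within the scatter). At this aromatic carbon, para to a large group, three heavy atoms of nitro give way to the one of chloro and the two hydrogen-bond acceptors leave, yet the number stays within the scatter, so compound 4 shows that nitro is not required here to hold the weak level seen with compound 3. No measurement on hand bears on why this exchange leaves the number in place.

As far as these compounds go, whether an amine or a carboxylic acid at this carbon would give a step beyond the scatter remains open. Also open, from the compounds shown here alone, is whether chloro in place of nitro would read the same with nitro placed as in compound 2.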